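Moving the chlorine on the pyridine ring of a weak growth inhibitor

The compounds below may be only part of what the source reports. "The series", "measured", "known", "first", "only" and "open" are said of these compounds alone.

Compound 2 `O=C(c1ccc(Cl)nc1)N1N=C(c2ccc(Cl)cc2)CC1c1ccc(OCc2ccccc2)cc1` in a functional assay on WM 266-4 cells (Homo sapiens) for antiproliferative activity, read by MTT assay, with a stated time of 24 h (a lower number here means a stronger inhibitor of growth, a higher number a weaker inhibitor of growth), gives 13200 nM. Compound 1 `O=C(c1cncc(Br)c1)N1N=C(c2ccc(Cl)cc2)CC1c1ccc(OCc2ccccc2)cc1` gives 8130 nM, and the step of a 1.6-fold higher number from compound 1 to compound 2 (0.21 log units; within the scatter) keeps the two within the scatter of each other. Compound 3 `O=C(c1cccnc1Cl)N1N=C(c2ccc(Cl)cc2)CC1c1ccc(OCc2ccccc2)cc1` is not yet measured; it differs from compound 2 by 2-chloropyridin-3-yl in place of 6-chloropyridin-3-yl on a carbonyl carbon. Among the measured compounds shown here, only the step from compound 1 to compound 2 touches the same pyridine carbonyl group, and it stayed within the scatter, so the expected step of a 1.1-fold lower number from compound 2 to compound 3 (0.04 log units; within the scatter) is small and has no clear direction. Compound 3 is therefore estimated at 12000 nM, with a range of 4000 nM to 40000 nM.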

Compound 3, concentration for 50% growth inhibition: 7710 nM
Compound 3: middle estimate off by 1.6-fold (0.19 log units), on the high side; the range from low to high includes it.
By their numbers in this assay, from the lowest: compounds 3, 1 and 2 (each within the scatter of the next).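

In this assay the change to 2-chloropyridin-3-yl on the carbonyl carbon gives a 1.7-fold lower number from compound 2 to compound 3 (0.23 log units; within the scatter) starting from 6-chloropyridin-3-yl and a 1.1-fold lower number from compound 1 to compound 3 (0.02 log units; within the scatter) starting from 5-bromopyridin-3-yl. Among the compounds shown here, this is the first comparison in which the same chlorine sits at a different place on the pyridine, and that move leaves the number within the scatter. All three halogen-bearing pyridines are thus not told apart here, and no measurement is available to explain the result. From the compounds shown here alone, whether an amine or a carboxylic acid in place of the halogen on this pyridine would move the number beyond the scatter remains open.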